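Swapping a hydroxy for a methyl on the shared core

This account rests on a few compounds, and the source may have more. Where it says the series, first, only, none or still open, it means among the compounds named here.

Of the compounds shown here, three have been measured in an assay on HEK293 cells for positive allosteric modulation of metabotropic glutamate receptor 2 (Rattus norvegicus), read by thallium flux, with a stated time of 2.5 min; a higher number here means a larger maximal response, a lower number a smaller maximal response. Compound 1 `Cc1c(OCCCCOc2ccc(C(=O)O)c(Cl)c2)ccc(C(=O)CC(C)C)c1C` gives 33.1%, compound 2 `Cc1c(OCCCCOc2ccc(F)c(C(=O)O)c2)ccc(C(=O)CC2CCCC2)c1C` gives 14.6%, and compound 3 `Cc1c(OCCCCOc2ccc(C(=O)O)c(Cl)c2)ccc(C(=O)CC2CCCC2)c1O` gives 80.8%, the highest of the three numbers, beyond the scatter above both others. Compound 4 `Cc1c(OCCCCOc2ccc(C(=O)O)c(Cl)c2)ccc(C(=O)CC2CCCC2)c1C` differs from compound 3 in one place: methyl in place of hydroxy on an aromatic carbon. The shift is to be measured in this assay. Going by the values given here, no directly comparable step between measured compounds is available, yet the two compounds that already carry the methyl, compound 1 with 33.1% and compound 2 with 14.6%, sit well below compound 3. For compound 4 a sizeable downward step is therefore expected, a number 40.8 percentage points lower from compound 3 to compound 4 (beyond the scatter), with an estimated maximal response of 40% in a range from 15% to 70%.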

Compound 4, largest response reached (reported as percent of maximum), in percent of the reference or control that the assay uses: 61.8%
Beside the measured number, compound 4's estimate is 21.8 percentage points below it; the range from low to high includes it.
By their numbers in this assay, from the lowest: compound 2; then compound 1; then compound 4; then compound 3.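

In this assay, the hydroxy is not essential for a response at this position: with methyl in its place there is a number 19 percentage points lower from compound 3 to compound 4 (beyond the scatter), and a clear response remains. The low numbers of the other methyl compounds therefore trace to other places, with a number 47.2 percentage points higher from compound 2 to compound 4 (beyond the scatter) for 4-carboxy-3-chlorophenyl replacing 3-carboxy-4-fluorophenyl, and a number 28.7 percentage points higher from compound 1 to compound 4 (beyond the scatter) for cyclopentyl replacing isopropyl. Nothing available explains why any of these changes shifts the response. Going by these compounds, whether a methoxy, an amine or a fluorine at this position would match the hydroxy remains open.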